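Adding a Methoxy Group to an Amino Chalcone

The source may hold more compounds than are shown below. What is called first, only, known or untested is meant among the compounds shown, and "the series" means these compounds.

Compound 1 `C=C(Br)C(=O)Nc1ccc(C(=O)/C=C/c2cccc(OC)c2)cc1` and compound 2 `C=C(Br)C(=O)Nc1ccc(C(=O)/C=C/c2cc(OC)cc(OC)c2)cc1` share one core, and compound 2 carries one more methoxy group. In a functional assay on MOLT-4 cells (Homo sapiens) for antiproliferative activity, with a stated time of 48 h (a lower number here means a stronger inhibitor, a higher number a weaker inhibitor), compound 1 gives 1100 nM, while compound 2 gives 1500 nM. The change between them is methoxy in place of hydrogen on an aromatic carbon, and it made a step of a 1.4-fold higher number from compound 1 to compound 2 (0.13 log units; within the scatter).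

Compound 3 `Nc1ccc(/C=C/C(=O)c2ccccc2)cc1` is built on a different core; the difference between the two cores is not broken down here. In this assay compound 3 gives 10000 nM, the highest number among the three measured compounds.

Compound 4 `COc1cccc(C(=O)/C=C/c2ccc(N)cc2)c1` has not been measured. It differs from compound 3 by methoxy in place of hydrogen on an aromatic carbon. Within the data shown here, this is the same kind of change as the one from compound 1 to compound 2, but not the same: in compound 2 the entering group also stands meta to a methoxy group, which is not so in compound 4.

The earlier step, a 1.4-fold higher number from compound 1 to compound 2 (0.13 log units; within the scatter), stayed within the scatter, and nothing among these compounds points to a larger effect on the new core. On that basis the expected step is a 1.1-fold lower number from compound 3 to compound 4 (0.05 log units; within the scatter). For compound 4 the estimated value in this assay is 9000 nM, with a likely range from 3000 nM to 30000 nM.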

Compound 4, half-maximal inhibitory concentration: 20000 nM
Compound 4: the middle estimate sits 2.2-fold (0.35 log units) below what was measured, within the range that was stated.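

Putting a methoxy group on an aromatic carbon of compound 3 gave a 2.0-fold higher number from compound 3 to compound 4 (0.30 log units; within the scatter) in this assay, so this step, like the earlier one, is no larger than the ordinary spread of repeated measurements. Set side by side, the two steps do not tell the cores apart: the same change on two cores in this assay, a 1.4-fold higher number (0.13 log units; within the scatter) from compound 1 to compound 2 and a 2.0-fold higher number (0.30 log units; within the scatter) from compound 3 to compound 4, 1.5-fold (0.17 log units) apart, within the scatter of two such steps. This shows that, in these two pairs, the change carried over from one core to the other without a step that can be told from scatter; it does not show that methoxy has no effect at all, or that the same would hold on a further core.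

The compounds shown leave open whether another group in the same place, such as a hydroxyl group, an amine or a longer chain like ethoxy, would give a step beyond the scatter. They also leave open which of the structural differences between the two cores matter in this assay.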